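The compounds below may be only part of what the source reports. "The series", "measured", "known", "first", "only" and "open" are said of these compounds alone.

Working notes on the series. Compound 2 `Cc1ccc(-c2cn(-c3ccc(CN4CCN(C)CC4)c(C(F)(F)F)c3)nn2)cc1Nc1nccc(-c2cccnc2)n1` carries a trifluoromethyl group and gives 30 nM in a functional assay on K562 cells (Homo sapiens) for inhibition, read by MTT assay, with a stated time of 72 h; a higher number here means a weaker inhibitor, a lower number a stronger inhibitor. Compound 1 `Cc1ccc(-c2cn(-c3ccc(CN4CCN(C)CC4)cc3)nn2)cc1Nc1nccc(-c2cccnc2)n1` differs from it in one place, (hydrogen in place of trifluoromethyl on an aromatic carbon), and in this assay compound 1 gives 4700 nM; the step is a 160-fold higher number from compound 2 to compound 1 (2.19 log units; beyond the scatter). Compound 3 `Cc1ccc(-c2nnc(-c3ccc(CN4CCN(CCN=C=S)CC4)c(C(F)(F)F)c3)o2)cc1Nc1nccc(-c2cccnc2)n1` has a different core from compound 2; the difference between the two cores is not broken down here. In this assay compound 3 gives 500 nM. Compound 4 `Cc1ccc(-c2nnc(-c3ccc(CN4CCN(CCN=C=S)CC4)cc3)o2)cc1Nc1nccc(-c2cccnc2)n1` is not yet measured; it differs from compound 3 in one place, (hydrogen in place of trifluoromethyl on an aromatic carbon). This is the same kind of change as from compound 2 to compound 1, though the place is described differently: in compound 1 the hydrogen sits ortho to a (4-methylpiperazin-1-yl)methyl group (8 heavy atoms), whereas in compound 4 it sits ortho to a large group. The step expected from compound 3 to compound 4 in this assay is a 30-fold higher number from compound 3 to compound 4 (1.48 log units; beyond the scatter), resting on the step of a 160-fold higher number from compound 2 to compound 1 (2.19 log units; beyond the scatter) and on the value of compound 3, 500 nM, with a wide band because the change is carried onto another core. Compound 4 is therefore estimated at 15000 nM, between 3000 nM and 80000 nM.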

Compound 4, half-maximal inhibitory concentration: 920 nM
For compound 4 the middle estimate is 16-fold (1.21 log units) above the measured one; the whole stated range lies above it.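

In this assay the replacement of trifluoromethyl by hydrogen on the second core gives a 1.8-fold higher number from compound 3 to compound 4 (0.26 log units; within the scatter). The large loss seen with this change on the first core therefore does not carry over, and the size of the step depends on the core it is made on, at least for these two pairs: the same change on two cores in this assay, a 160-fold higher number (2.19 log units; beyond the scatter) from compound 2 to compound 1 and a 1.8-fold higher number (0.26 log units; within the scatter) from compound 3 to compound 4, 85-fold (1.93 log units) apart, beyond the scatter of two such steps

This does not show which part of the structures sets the gap, as the two cores differ in more than one place, and two pairs cannot show which of the two steps is more typical for the series.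

From the compounds shown here alone, it remains open whether chlorine or a methoxy group at the same place would follow compound 1 or compound 4 in this comparison. Also open, going by these compounds, is how the change behaves on a core that keeps the first core's methyl group on the piperazine but carries the second core's central ring, or the reverse.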